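The compounds below may be only part of what the source reports. "The series", "measured", "known", "first", "only" and "open" are said of these compounds alone.

Measured compounds:
- compound 1, `Cc1cc(C)nc(NC[C@@H]2CC3(CC3)CN2C(=O)c2nc(C)sc2-c2ccccc2)n1`: 8.6
- compound 2, `O=C(c1ncccc1-c1ncccn1)N1CC2(CC2)C[C@H]1CNc1ccc(C(F)(F)F)cn1`: 5

Compound 1 is the higher of the two numbers in a functional assay on HEK293 cells for antagonist activity at Orexin receptor type 2 (Homo sapiens), read by FLIPR and calcium flux; on this read-out lower numbers stand for lower potency and higher numbers for higher potency (the scale is a negative logarithm); compound 2 stands well below it, a gap beyond the usual scatter. Compound 3, `Cc1nc(C(=O)N2CC3(CC3)C[C@H]2CNc2cc(C(F)(F)F)ccn2)c(-c2ccccc2)s1`, has not been measured. It differs from compound 1 by 4-(trifluoromethyl)pyridin-2-yl in place of 4,6-dimethylpyrimidin-2-yl on an amine nitrogen, a change on an amine nitrogen whose other neighbour is a saturated chain carbon. For the measured compounds named here, no measured pair isolates this change, so the step can only be estimated. In this assay compound 3 is expected to come in somewhat lower, an estimated step of a number 0.60 log units lower from compound 1 to compound 3 (beyond the scatter), giving an estimate of 8 with a range from 7.2 to 8.8.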

Compound 3, negative logarithm of the antagonist equilibrium constant: 8.5
For compound 3 the middle estimate is 0.50 log units below the measured one, within the range that was stated.
By their numbers in this assay, from the lowest: compound 2; then compounds 3 and 1 (each within the scatter of the next).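

In this assay, 4-(trifluoromethyl)pyridin-2-yl in place of 4,6-dimethylpyrimidin-2-yl on the amine nitrogen gives a number 0.10 log units lower from compound 1 to compound 3 (within the scatter). For the compounds shown here, this is the first pair here to isolate this position, and it shows that the position takes either group, with one ring hetero atom or two, and the two compounds stand level. Nothing available accounts for this result. The compounds shown leave open how a phenyl ring or an acetyl group on this amine nitrogen would read, and whether the two groups also stand level on another core.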